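A Chlorophenyl for a Methylphenyl on a Weak Amide Pair

A few compounds are considered here, and "the series" means these few. Any claim that something is new, unique, unknown or untested is made for them only; others in the source may bear on it.

Compound 2 `Cc1ccc(-c2ccc(CCC(=O)N3CCCC3)cc2)cc1` is one of two measured amides. In an assay on HEK293 cells for inhibition of N-acylethanolamine-hydrolyzing acid amidase (Rattus norvegicus), read by LC-MS, with a stated time of 30 min (a higher number here means a weaker inhibitor, a lower number a stronger inhibitor), compound 2 gives 33200 nM. Its nearest neighbour, compound 1 `O=C(CCCCCCc1ccc(Cl)cc1)N1CCCC1`, gives 34500 nM in this assay, a number that sits within the scatter of the value for compound 2, so the two cannot be told apart. Compound 3 `O=C(CCc1ccc(-c2ccccc2Cl)cc1)N1CCCC1` carries 2-chlorophenyl in place of 4-methylphenyl on an aromatic carbon. Among the measured compounds shown here, no measured pair shows this exchange, so its size is unknown from the data. The change is expected to bring nothing beyond the scatter, and the estimated step of a 1.0-fold lower number from compound 2 to compound 3 (0.02 log units; within the scatter) is accordingly small. The expected value for compound 3 is 32000 nM, with a range from 10000 nM to 100000 nM.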

Compound 3, half-maximal inhibitory concentration: > 100000 nM
Compound 3: only a limit was reported (the forecaster's own chance of this, stated with the estimate: 20%); middle value at least 3.1-fold (0.49 log units) away from the limit.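

Putting 2-chlorophenyl in place of 4-methylphenyl at this position, para to a group of 9 heavy atoms, is not a silent exchange: in this assay it gives an at least 3.0-fold higher number from compound 2 to compound 3 (0.47 log units; beyond the scatter). The two groups match in heavy-atom count and in having one aromatic ring each, so these counts alone do not tell the outcome. The reading for compound 3 is a limit and not a number: the limit of > 100000 nM in this assay, at which 1 of the 3 values shown sits.

On these data alone, what stays open is whether the chlorine or its place on the ring sets this step. A 2-methylphenyl or a plain phenyl at this position would help to separate the two.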